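The compounds below may be only part of what the source reports. "The series", "measured", "known", "first", "only" and "open" are said of these compounds alone.

Working notes on the series.

The shared core carries two arylidene arms and a sulfonyl group; compound 1 `Cc1ccc(S(=O)(=O)N2C/C(=C\c3cccnc3)C(=O)/C(=C/c3ccccc3F)C2)cc1` is the reference. In a functional assay on QGY-7703 cells (Homo sapiens) for cytotoxicity, read by MTT assay, with a stated time of 24 h (on this read-out higher numbers stand for weaker inhibition and lower numbers for stronger inhibition), compound 1 gives 9700 nM. Compound 2 `O=C1/C(=C/c2cccnc2)CN(S(=O)(=O)c2ccc([N+](=O)[O-])cc2)C/C1=C\c1ccccc1F` differs from compound 1 by nitro in place of methyl on an aromatic carbon, and in this assay compound 2 gives 5600 nM; the step is a 1.7-fold lower number from compound 1 to compound 2 (0.24 log units; within the scatter). Compound 3 `Cc1ccc(S(=O)(=O)N2C/C(=C\c3cccnc3)C(=O)/C(=C/c3ccccc3C(F)(F)F)C2)cc1` differs from compound 1 by trifluoromethyl in place of fluoro on an aromatic carbon, and in this assay compound 3 gives 6170 nM; the step is a 1.6-fold lower number from compound 1 to compound 3 (0.20 log units; within the scatter). The values of compound 2 and compound 3 lie within the scatter of each other, so no order between them is read. All three measured compounds sit close together on this read-out.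

Compound 4 `O=C1/C(=C/c2cccnc2)CN(S(=O)(=O)c2ccc([N+](=O)[O-])cc2)C/C1=C\c1ccccc1C(F)(F)F` has not been measured. It differs from compound 3 by nitro in place of methyl on an aromatic carbon. This is the same change as that from compound 1 to compound 2: the group that leaves, the group that enters and the place are described in identical words, while the cores of the two pairs differ by trifluoromethyl in place of fluoro on an aromatic carbon. For the measured compounds named here, the one prior example of this change, a 1.7-fold lower number from compound 1 to compound 2 (0.24 log units; within the scatter), stayed within the scatter, and the core change a 1.6-fold lower number from compound 1 to compound 3 (0.20 log units; within the scatter) also stayed within the scatter, so no interaction between the two changes can be read from what is known.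

For compound 4 in this assay the expected step is a 1.7-fold lower number from compound 3 to compound 4 (0.23 log units; within the scatter), resting on the earlier step of a 1.7-fold lower number from compound 1 to compound 2 (0.24 log units; within the scatter) applied to compound 3 at 6170 nM. Compound 4 is therefore estimated at 3600 nM, with the range 1800 nM to 8000 nM expected to hold most repeat measurements.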

Compound 4, half-maximal inhibitory concentration: 7660 nM
The estimate for compound 4 lay 2.1-fold (0.33 log units) below the measured number; the measured number falls inside the stated range.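

Carried onto the core of compound 3 in this assay, nitro in place of methyl gives a 1.2-fold higher number from compound 3 to compound 4 (0.09 log units; within the scatter), and the step does not differ measurably from its earlier counterpart: the same change on two cores in this assay, a 1.7-fold lower number (0.24 log units; within the scatter) from compound 1 to compound 2 and a 1.2-fold higher number (0.09 log units; within the scatter) from compound 3 to compound 4, 2.2-fold (0.33 log units) apart, within the scatter of two such steps

Carried onto the core of compound 2, trifluoromethyl in place of fluoro gives a 1.4-fold higher number from compound 2 to compound 4 (0.14 log units; within the scatter), and this step likewise does not differ measurably from its earlier counterpart: the same change on two cores in this assay, a 1.6-fold lower number (0.20 log units; within the scatter) from compound 1 to compound 3 and a 1.4-fold higher number (0.14 log units; within the scatter) from compound 2 to compound 4, 2.2-fold (0.33 log units) apart, within the scatter of two such steps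

Across these four compounds, neither change is seen to depend on the core, but this does not show that either change carries a real effect from one core to another, as every step stays within the scatter and the opposite signs of the paired steps cannot be read as a reversal.

The compounds shown leave open whether an amine or a carboxylic acid in place of methyl or nitro on the aromatic ring of the sulfonyl group would give a step beyond the scatter in this assay. Going by these compounds, it is equally open whether a chloro group or a nitrile in place of fluoro or trifluoromethyl would do so, and whether any such step would hold on both cores.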